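A few compounds are considered here, and "the series" means these few. Any claim that something is new, unique, unknown or untested is made for them only; others in the source may bear on it.

Compound 2, `C/C(=N\OCC(=O)N[C@H](C(=O)N[C@@H](CCCCN)C(=O)N1CCC[C@H]1C(=O)N[C@@H](CCCCN)C(=O)NCC(=O)O)[C@@H](C)O)c1ccc(NC(=O)c2cc(Br)ccc2O)cc1`, is a peptide conjugate carrying a bromo-substituted salicylanilide, and in a functional assay on HepG2 cells (Homo sapiens) for cytotoxicity, read by MTT assay, with a stated time of 24 h (a higher number here means a weaker inhibitor, a lower number a stronger inhibitor), compound 2 gives 191000 nM. That is the highest of the three numbers recorded here. Compound 1, `O=Cc1ccc(O)c(C(=O)Nc2ccc(C(F)(F)F)cc2)c1`, gives 17600 nM in this assay, and stands nearest to compound 2, though the gap is beyond the scatter. Compound 3, `CC(=O)c1ccc(NC(=O)c2cc(Cl)ccc2O)cc1`, gives 7900 nM in this assay and is furthest away, again beyond the scatter. Neither of these pairs is a single-point change, so only the values themselves can be compared.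

Compound 4, `C/C(=N\OCC(=O)N[C@H](C(=O)N[C@@H](CCCCN)C(=O)N1CCC[C@H]1C(=O)N[C@@H](CCCCN)C(=O)NCC(N)=O)[C@@H](C)O)c1ccc(NC(=O)c2cc(Br)ccc2O)cc1`, differs from compound 2 in one place: amino in place of hydroxy on a carbonyl carbon. The rest of the molecule, including the peptide chain and the salicylanilide, is kept. Among the measured compounds shown here, no measured pair in this set shows the effect of exchanging hydroxy for amino on a carbonyl carbon, so there is no direct precedent to lean on.

Given that the change is confined to one heavy atom at the end of the chain, compound 4 is expected to sit close to compound 2, with the step of a 1.3-fold lower number from compound 2 to compound 4 (0.10 log units; within the scatter) expected to lie within or barely beyond the scatter. Compound 4 is therefore estimated at 150000 nM in this assay, with a range from 60000 nM to 400000 nM.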

Compound 4, half-maximal inhibitory concentration: > 200000 nM
Compound 4 was reported as a limit; the forecaster's own chance of this, stated with the estimate: 10%; at least 1.3-fold (0.12 log units) between middle value and limit.
By their numbers in this assay, from the lowest: compound 3; then compound 1; then compound 2. At a limit, above all of these: compound 4.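

In this assay compound 4 is recorded only as a limit, > 200000 nM, and that is not a number. The step for amino in place of hydroxy on a carbonyl carbon is an at least 1.0-fold higher number from compound 2 to compound 4 (0.01 log units; that floor lies within the scatter), which gives this exchange its first reading in the set: carboxy to carbamoyl at the end of the peptide chain brought no measurable move towards a lower number, but the true size of any rise cannot be read from a floor that small. The position therefore takes carbamoyl as well as carboxy with the conjugate staying at the very top of the values recorded, and the reading ends where the assay's range ends: the limit of > 200000 nM in this assay, at which 1 of the 4 values shown sits.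

The compounds shown leave open where compound 4 truly lies, and so whether the exchange does anything at all in this assay. They also leave open how a methyl ester or a longer chain ending in a carboxylic acid would read at this position, and whether carboxy to carbamoyl would read the same with chloro in place of bromo on the salicylanilide.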